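The source may report more compounds than this note shows. Statements on the series, on what has been measured and on what is new or still open speak of the compounds shown alone.

Compound 1 `O=C(NCCNS(=O)(=O)c1sccc1-c1ccccc1Oc1ccc(O)c(O)c1)Nc1cc(Cl)cc(Cl)c1` and compound 2 `Cc1ccc(-c2ccsc2S(=O)(=O)NCCNC(=O)Nc2cc(Cl)cc(Cl)c2)c(Oc2ccc(O)c(O)c2)c1` share one core, while compound 3 `O=S(=O)(NCCNC(=S)Nc1cc(C(F)(F)F)cc(C(F)(F)F)c1)c1sccc1-c1ccccc1Oc1ccc(O)c(O)c1` is built on another; the difference between the two cores is not broken down here. In a functional assay on HL-60 cells (Homo sapiens) for inhibition, read by CCK-8 assay, with a stated time of 48 h (on this read-out lower numbers stand for stronger inhibition and higher numbers for weaker inhibition), compound 1 gives 6900 nM, and compound 2 gives 3500 nM. Compound 2 differs from compound 1 by methyl in place of hydrogen on an aromatic carbon and that change made a 2.0-fold lower number from compound 1 to compound 2 (0.29 log units; within the scatter). In this assay compound 3 gives 4300 nM. Compound 4 `Cc1ccc(-c2ccsc2S(=O)(=O)NCCNC(=S)Nc2cc(C(F)(F)F)cc(C(F)(F)F)c2)c(Oc2ccc(O)c(O)c2)c1` has not yet been measured; it differs from compound 3 by methyl in place of hydrogen on an aromatic carbon which is the same change at the same kind of place as the one seen between the first two compounds. For compound 4 the expected step is a 1.7-fold lower number from compound 3 to compound 4 (0.24 log units; within the scatter), because the earlier identical change gave a 2.0-fold lower number from compound 1 to compound 2 (0.29 log units; within the scatter). Compound 4 is therefore estimated at 2500 nM, most likely between 1200 nM and 5500 nM.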

Compound 4, half-maximal inhibitory concentration: 3200 nM
The estimate for compound 4 lay 1.3-fold (0.11 log units) below the measured number; the measured number falls inside the stated range.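

In this assay, putting the methyl group on the core of compound 3 gives a 1.3-fold lower number from compound 3 to compound 4 (0.13 log units; within the scatter). Set beside the same change on the other core, the two steps agree: the same change on two cores in this assay, a 2.0-fold lower number (0.29 log units; within the scatter) from compound 1 to compound 2 and a 1.3-fold lower number (0.13 log units; within the scatter) from compound 3 to compound 4, 1.5-fold (0.17 log units) apart, within the scatter of two such steps So the change carries from one core to the other without a detectable difference, but each step on its own lies within the scatter, which means the pair does not show that the methyl group really alters the read-out on either core, and two cores cannot establish a general rule. The compounds shown leave open whether a larger group at the same place, such as ethyl or methoxy, or a chlorine atom, would give a step beyond the scatter. They also leave open how the methyl group would behave on a third core.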